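The source may hold more compounds than are shown below. What is called first, only, known or untested is meant among the compounds shown, and "the series" means these compounds.

Compound 1 `C/C(=N\NC(=O)c1ccc(-c2ccccc2)cc1)c1ccccc1O`: 2700 nM
Compound 2 `C/C(=N\NC(=O)c1cccc2ccccc12)c1ccccc1O`: 3900 nM
Compound 3 `C/C(=N\NC(=O)c1cnccn1)c1ccccc1O`: 22300 nM

All three were tested in a functional assay on HL-60 cells (Homo sapiens) for cytotoxicity, read by MTT assay, with a stated time of 72 h; a higher number here means a weaker inhibitor, a lower number a stronger inhibitor. Compound 1 gives the lowest number of the three; compound 2 sits within the scatter of it, while compound 3 lies well beyond it, so only the gap to compound 3 counts as a real difference. Compound 4 `CC/C(=N\NC(=O)c1ccc(-c2ccccc2)cc1)c1ccccc1O` has not yet been measured. It differs from compound 1 in one place: methyl in place of hydrogen on a saturated chain carbon bound to a carbon with a double bond to nitrogen. For the measured compounds named here, no measured pair here differs in that way, so there is no precedent to lean on. Such a small addition is expected to stay within the scatter, with no clear direction. The step of a 1.1-fold higher number from compound 1 to compound 4 (0.05 log units; within the scatter) is the estimate. Compound 4 is expected to give about 3000 nM, between 1200 nM and 7500 nM, in this assay.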

Compound 4, half-maximal inhibitory concentration: 1300 nM
Beside the measured number, compound 4's estimate is 2.3-fold (0.36 log units) above it, and the stated range covers the measured number.
By their numbers in this assay, from the lowest: compound 4; then compounds 1 and 2 (each within the scatter of the next); then compound 3.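

In this assay, putting methyl in place of hydrogen on a saturated chain carbon bound to a carbon with a double bond to nitrogen gives a 2.1-fold lower number from compound 1 to compound 4 (0.32 log units; beyond the scatter), a modest step but one beyond the scatter. This position therefore responds to change: turning methyl into ethyl, with just one added carbon, is enough to lower the number. Nothing available here explains why.

Going by these compounds, whether a longer chain, such as propyl, would lower the number further remains open. So does the effect of an amine or a carboxylic acid on this chain.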